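This account rests on a few compounds, and the source may have more. Where it says the series, first, only, none or still open, it means among the compounds named here.

Working notes on a small series sharing one core, read in a functional assay on a cell-free system (plasma, Oryctolagus cuniculus) for inhibition, with stated times of 5 min, 1 min and 6 min; on this read-out lower numbers stand for stronger inhibition and higher numbers for weaker inhibition. Compound 1 `CCOC(=O)c1c(C)nc(-c2cccc(C#N)c2)n1C` gives 22100 nM, compound 2 `CCOC(=O)c1c(C)nc(-c2cccc(C#N)c2)n1C(C)C` gives 9260 nM, and compound 3 `CCOC(=O)COn1c(-c2cccc(C#N)c2)nc(C)c1C(=O)OCC` gives 6800 nM. Compound 3 and compound 2 are level within the scatter, and both have lower numbers than compound 1.

The next compound is compound 4 `CCOC(=O)c1c(C)nc(-c2cccc(C#N)c2)n1OCC(N)=O`, with the change amino in place of ethoxy on a carbonyl carbon, which turns (ethoxycarbonyl)methoxy into carbamoylmethoxy.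

The measured steps bear on this only indirectly, since each exchanges the whole group on the aromatic nitrogen and none replaces ethoxy with amino. The largest is a 3.3-fold lower number from compound 1 to compound 3 (0.51 log units; beyond the scatter), which is modest, and a 2.4-fold lower number from compound 1 to compound 2 (0.38 log units; beyond the scatter) is also modest. Exchanging isopropyl for the full (ethoxycarbonyl)methoxy group gave only a 1.4-fold lower number from compound 2 to compound 3 (0.13 log units; within the scatter). Among the measured compounds shown here, on that evidence, the smaller edit in compound 4 is expected to give no step beyond the scatter in this assay, with only a slight lean towards a higher number and no measured step to support that direction.

The step this estimate implies is expected to be a 1.3-fold higher number from compound 3 to compound 4 (0.10 log units; within the scatter). The estimated value for compound 4 is 8500 nM, with an expected range of 3000 nM to 24000 nM.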

Compound 4, half-maximal inhibitory concentration: > 30000 nM
Compound 4: only a limit was reported (the forecaster's own chance of this, stated with the estimate: 10%); middle value at least 3.5-fold (0.54 log units) from the limit.
By their numbers in this assay, from the lowest: compounds 3 and 2 (each within the scatter of the next); then compound 1. At a limit, above all of these: compound 4.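

Among the compounds shown here, compound 4 is reported in this assay only as a limit, the one such value in this set: the limit of > 30000 nM in this assay, at which 1 of the 4 values shown sits. Replacing ethoxy with amino on a carbonyl carbon gives an at least 4.4-fold higher number from compound 3 to compound 4 (0.64 log units; beyond the scatter) and so separates two closely related groups on the aromatic nitrogen, whereas the earlier exchanges of the whole group produced only modest steps or none beyond the scatter. The same limit gives an at least 3.2-fold higher number from compound 2 to compound 4 (0.51 log units; beyond the scatter) as well, so carbamoylmethoxy is the first group shown to move the number upwards, though an at least 1.3-fold higher number from compound 1 to compound 4 (0.13 log units; that floor lies within the scatter) fixes only a floor and leaves that order unsettled.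

The true value for compound 4 remains unknown, so the full size of these steps stays open, and the compounds shown do not separate the effect of removing ethoxy from that of introducing amino. A carboxylic acid, a methylamino or dimethylamino group on the same carbonyl carbon, or a longer ester chain in place of ethoxy would each bear on that question.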